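The compounds below may be only part of what the source reports. "The series", "measured", "known", "first", "only" and "open" are said of these compounds alone.

For the measured compounds named here, in an ADME assay on BJ cells (Homo sapiens) for cytotoxicity, read by CellTiter-Glo and resazurin assay, with a stated time of 72 h (on this read-out higher numbers stand for an effect only at larger amounts of compound and lower numbers for an effect already at smaller amounts), none of the three compounds tested so far gives a plain number. Compound 3 `CCOC(=O)CCCCCOc1cccc(CN(C(=O)c2ccc(-c3cccc(N(C)C)c3)cc2)C(C)C)c1` gives > 26000 nM, which is a limit of the assay and not a number. Compound 1 `CC(C)N(Cc1cccc(OCCCCCC(=O)O)c1)C(=O)c1ccc(-c2cccc(N(C)C)c2)cc1` gives > 26000 nM, also a limit. Compound 2 `CC(C)N(Cc1cccc(OCCCCCC(=O)O)c1)C(=O)c1ccc(-c2cccc(Cl)c2)cc1` gives > 21900 nM, again a limit.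

The next step leads from compound 3 to compound 4 `CCOC(=O)CCCCCOc1cccc(CN(C(=O)c2ccc(-c3ccncc3)cc2)C(C)C)c1`: pyridin-4-yl in place of 3-(dimethylamino)phenyl on an aromatic carbon. Pyridin-4-yl takes the place of 3-(dimethylamino)phenyl on an aromatic carbon, para to a large group.

Going by the values given here, two measured steps bear on this change. The closer one is a step that the two limits leave unreadable from compound 1 to compound 2, where chloro replaces dimethylamino on an aromatic carbon, so it alters the group that leaves here. The other is a step that the two limits leave unreadable from compound 1 to compound 3, where ethyl replaces hydrogen on an oxygen next to a carbonyl group. Neither step has a readable size, so neither points in a direction, and no step beyond the scatter is expected in this assay.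

That expectation rests on compound 3, whose limit is > 26000 nM. The expected change is a step that the limit leaves unreadable from compound 3 to compound 4. For compound 4 the estimated value is 30000 nM, within an expected range of 15000 nM to 60000 nM, and another limit is the likeliest report.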

Compound 4, half-maximal effective concentration: > 26000 nM
Compound 4 gave a limit, no number (the forecaster's own chance of this, stated with the estimate: 85%); the middle value does not contradict the limit.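

In this assay compound 3 and compound 4 each give a limit of the assay rather than a number, so the step between them cannot be read, and the swap of 3-(dimethylamino)phenyl for pyridin-4-yl has no visible size or direction. The compounds shown leave open at what concentration, if any, each would affect these cells.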